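The compounds below may be only part of what the source reports. "The series", "measured", "known", "first", "only" and "open" are said of these compounds alone.

Compound 1 `COc1ccc(CN2C(=O)C(=O)c3cc(-c4ccc(OC)c(OC)c4)ccc32)cc1`: > 10000 nM
Compound 2 `COc1ccc(CN2C(=O)C(=O)c3cc(-c4ccc(C)cc4)ccc32)cc1`: > 10000 nM

Both compounds were tested in a functional assay on HepG2 cells (Homo sapiens) for antiproliferative activity, read by MTT assay, with a stated time of 48 h; a higher number here means a weaker inhibitor, a lower number a stronger inhibitor. Compound 1 gives > 10000 nM, which is a limit of the assay and not a number. Compound 2 gives > 10000 nM, which is also a limit. Among the measured compounds shown here, the one measured step, a step that the two limits leave unreadable from compound 1 to compound 2, therefore offers no size to reason from, and the evidence amounts to the limit of > 10000 nM in this assay, at which 2 of the 2 values shown sit.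

Compound 3 `COc1ccc(CN2C(=O)C(=O)c3cc(-c4ccc(C(F)(F)F)cc4)ccc32)cc1` has trifluoromethyl in place of methyl on an aromatic carbon, para to a large group, as compound 2 is changed by trifluoromethyl in place of methyl on an aromatic carbon. For the measured compounds named here, no measured step bears directly on this change. Because compound 2 stands at > 10000 nM, no readable step in either direction is expected in this assay. The expected step, a step that the limit leaves unreadable from compound 2 to compound 3, is only an estimate set against a limit. For compound 3 the estimated value is 15000 nM, with an expected range from 5000 nM to 40000 nM.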

Compound 3, half-maximal inhibitory concentration: 820 nM
The estimate for compound 3 lay 18-fold (1.26 log units) above the measured number; measured number below the stated range.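

In this assay there is an at least 12-fold lower number from compound 2 to compound 3 (1.08 log units; beyond the scatter), with trifluoromethyl in place of methyl, so this place, para to a large group, can carry a change that brings a compound off the limit. There is likewise an at least 12-fold lower number from compound 1 to compound 3 (1.08 log units; beyond the scatter), with 4-(trifluoromethyl)phenyl in place of 3,4-dimethoxyphenyl, so the same result appears against both earlier compounds. The step from compound 1 to compound 2 cannot be read, and the two readable steps give only a minimum size, since each starts from a limit: the limit of > 10000 nM in this assay, at which 2 of the 3 values shown sit.

The compounds shown leave open whether trifluoromethyl is alone in this, or whether a nitrile or a chlorine atom at the same place would also leave the limit. Also open, as far as these compounds go, is whether the methoxy group shared by all three compounds could give way to an amine while keeping the value of compound 3, 820 nM.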